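Aryl hydrazone acid series: methyl for nitro on the ring

The source may hold more compounds than are shown below. What is called first, only, known or untested is meant among the compounds shown, and "the series" means these compounds.

Measured so far:
- compound 1, `CCOC(=O)/C(CCCC(=O)O)=N\Nc1cccc(Cl)c1`: 20000 nM
- compound 2, `CCOC(=O)/C(CCCC(=O)O)=N\Nc1ccc([N+](=O)[O-])cc1`: 179000 nM

Both numbers come from an assay on isolated protein for inhibition of kynurenine--oxoglutarate transaminase 1 (Homo sapiens), read by HPLC, with a stated time of 20 min; a lower number here means a stronger inhibitor, a higher number a weaker inhibitor. Compound 2 stands highest of the two values; its nearest neighbour, compound 1, gives a number well below it, a gap beyond the scatter. Compound 3, `CCOC(=O)/C(CCCC(=O)O)=N\Nc1ccc(C)cc1`, is not yet measured in this assay. It differs from compound 2 by methyl in place of nitro on an aromatic carbon. Within the data shown here, no step between measured compounds is known, so the expectation rests on compound 2 alone; a moderate step toward a lower number, a 3.0-fold lower number from compound 2 to compound 3 (0.47 log units; beyond the scatter), is expected, beyond the scatter. For compound 3 the estimate is 60000 nM, within 15000 nM to 250000 nM.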

Compound 3, half-maximal inhibitory concentration: 33000 nM
Compound 3: the middle estimate sits 1.8-fold (0.26 log units) above what was measured, and the stated range covers the measured number.
By their numbers in this assay, from the lowest: compounds 1 and 3 (each within the scatter of the next); then compound 2.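

In this assay, methyl in place of nitro on an aromatic carbon, para to a large group, gives a 5.4-fold lower number from compound 2 to compound 3 (0.73 log units; beyond the scatter) here, so this position does respond to the change. 4-methylphenyl in place of 3-chlorophenyl on an amine nitrogen gives a 1.7-fold higher number from compound 1 to compound 3 (0.22 log units; within the scatter) and so does not separate these two aryl groups. Nothing measured here explains the step away from nitro. From the compounds shown here alone, whether an amine or a methoxy group at this same position would track with methyl or with nitro remains open. Also open, going by these compounds, is whether this step carries over to other ring positions.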